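Lengthening the Chain Once More

A few compounds are considered here, and "the series" means these few. Any claim that something is new, unique, unknown or untested is made for them only; others in the source may bear on it.

Two compounds share one core and differ only in the length of a saturated chain on a ring nitrogen. Compound 1, `CCCCCCCCN1NN=C(NC(=O)Nc2c(C(C)C)cccc2C(C)C)N1`, gives 59 nM in an assay on microsomes from intestine for inhibition of acyl-CoA:cholesterol acyltransferase (Oryctolagus cuniculus); on this read-out lower numbers stand for stronger inhibition and higher numbers for weaker inhibition. Compound 2, `CCCCCCCCCN1NN=C(NC(=O)Nc2c(C(C)C)cccc2C(C)C)N1`, gives 31 nM in this assay. The step of a 1.9-fold lower number from compound 1 to compound 2 (0.28 log units; within the scatter) goes with methyl in place of hydrogen on a saturated chain carbon, eight bonds along the chain from an amine nitrogen in a ring. On the numbers shown, compound 2 stands at the lower figure, yet its gap to compound 1 lies within the scatter, so the two count as alike.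

Compound 3, `CCCCCCCCCCN1NN=C(NC(=O)Nc2c(C(C)C)cccc2C(C)C)N1`, carries the same chain one carbon further: methyl in place of hydrogen on a saturated chain carbon, nine bonds along the chain from an amine nitrogen in a ring. Among the compounds with values here, only one measured step bears on this change, the one from compound 1 to compound 2, and it was small. A further single carbon is therefore expected to leave the number close to that of compound 2, with no shift beyond the scatter, or at most a modest one. Compound 3 is expected to give 25 nM, between 10 nM and 60 nM, amounting to an estimated step of a 1.2-fold lower number from compound 2 to compound 3 (0.09 log units; within the scatter).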

Compound 3, half-maximal inhibitory concentration: 14 nM
For compound 3 the middle estimate is 1.8-fold (0.25 log units) above the measured one; the range from low to high includes it.
By their numbers in this assay, from the lowest: compound 3; then compounds 2 and 1 (each within the scatter of the next).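

In this assay, one more carbon at this place now gives a step that clears the scatter, a 2.2-fold lower number from compound 2 to compound 3 (0.35 log units; beyond the scatter), where the earlier step alone could not be told apart from repeat-measurement noise. Read across the whole change, ethyl in place of hydrogen on the saturated chain carbon eight bonds along the chain from the amine nitrogen in the ring gives a 4.2-fold lower number from compound 1 to compound 3 (0.62 log units; beyond the scatter), so among these three compounds a longer chain goes with a lower number, and none of them goes against that pattern. Nothing available here explains why the number falls as the chain grows.

As far as these compounds go, whether a still longer chain would lower the number further, level off or reverse the trend remains open, and so does the length at which any such turn would come. Also open, from the compounds shown here alone, is how a chain ending in an amine or a carboxylic acid, rather than in the plain methyl end of compound 3, would behave at this place on the shared core.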